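The compounds below may be only part of what the source reports. "The series", "measured", "known", "first", "only" and "open" are said of these compounds alone.

Compound 2 `O=C1O[C@H]([C@@H](O)Cn2cc(C3CC3)nn2)C(OCc2ccccc2)=C1OCc1ccccc1` gives 26500 nM in a functional assay on HeLa cells (Homo sapiens) for antiproliferative activity, read by MTT assay, with a stated time of 72 h (a lower number here means a stronger inhibitor, a higher number a weaker inhibitor), the lowest of the two numbers in hand. Compound 1 `O=C1O[C@H]([C@@H](O)Cn2cc(-c3cccc(O)c3)nn2)C(OCc2ccccc2)=C1OCc1ccccc1` gives 39300 nM in this assay, and the step of a 1.5-fold lower number from compound 1 to compound 2 (0.17 log units; within the scatter) stays within the scatter. Compound 3 `Cc1ccc(S(=O)(=O)NCc2cn(C[C@H](O)[C@H]3OC(=O)C(OCc4ccccc4)=C3OCc3ccccc3)nn2)cc1` carries (((4-methylphenyl)sulfonyl)amino)methyl in place of cyclopropyl on an aromatic carbon. Going by the values given here, no measured step exchanges cyclopropyl for a group of this kind; the only step in hand concerns a different exchange on the same carbon and was small. The expected step is a 1.1-fold lower number from compound 2 to compound 3 (0.03 log units; within the scatter), which stays within the scatter. The estimate for compound 3 is 25000 nM, with a range from 10000 nM to 60000 nM.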

Compound 3, half-maximal inhibitory concentration: 14400 nM
Beside the measured number, compound 3's estimate is 1.7-fold (0.24 log units) above it; low and high end bracket the measured number.
By their numbers in this assay, from the lowest: compounds 3, 2 and 1 (each within the scatter of the next, the first and the last beyond it).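

In this assay the aromatic carbon of the five-membered ring accepts (((4-methylphenyl)sulfonyl)amino)methyl, the largest group shown so far at this place, with no loss of activity. Against cyclopropyl this group gives a 1.8-fold lower number from compound 2 to compound 3 (0.26 log units; within the scatter) and against 3-hydroxyphenyl it gives a 2.7-fold lower number from compound 1 to compound 3 (0.44 log units; beyond the scatter) as the first step in the series beyond the scatter, though still a modest one.

From the compounds shown here alone, whether a simple amine or a carboxylic acid on the same methylene, or a longer chain ending in the 4-methylphenyl ring, would keep this activity remains open. Nothing available explains either step.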